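The compounds below may be only part of what the source reports. "The series", "measured", "known", "first", "only" and "open" are said of these compounds alone.

Compound 1 `COC(=O)c1cc(-c2cccc(NC(=O)c3ccc(/C=C/C(=O)c4ccc(OC)cc4)cc3)c2)on1` gives > 10 ug/mL in an ADME assay on Vero cells (Chlorocebus sabaeus) for cytotoxicity, read by MTT assay, with a stated time of 72 h (a higher number here means that more compound is tolerated, a lower number that less compound is tolerated), which is a limit of the assay rather than a number.
Compound 2 `COC(=O)c1cc(-c2cccc(NC(=O)c3ccc(/C=C/C(=O)c4ccc(C)c(F)c4)cc3)c2)on1` gives > 50 ug/mL in this assay, again a limit.

Compound 2 thus stands at the limit of > 50 ug/mL in this assay, at which 1 of the 2 values shown sits, while compound 1 sits at the limit of > 10 ug/mL in this assay, at which 1 of the 2 values shown sits, so the step that the two limits leave unreadable from compound 1 to compound 2 cannot be read. Compound 3 `COC(=O)c1cc(-c2cccc(NC(=O)c3ccc(/C=C/C(=O)c4ccc(F)cc4F)cc3)c2)on1` differs from compound 2 by 2,4-difluorophenyl in place of 3-fluoro-4-methylphenyl on a carbonyl carbon. Among the measured compounds shown here, no measured step bears readably on this change, so no step beyond the scatter is expected in this assay. The expected step is a step that the limit leaves unreadable from compound 2 to compound 3. Compound 3 is therefore estimated at 60 ug/mL, with a range from 20 ug/mL to 150 ug/mL, and a limit is again likely.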

Compound 3, half-maximal cytotoxic concentration: > 40 ug/mL
Compound 3 ended at the assay's limit; the forecaster's own chance of this, stated with the estimate: 70%; the middle value does not contradict the limit.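

Among the compounds shown here, compound 1, compound 2 and compound 3 all end at limits of this assay, not at numbers, so no step among them can be read. Going by these compounds, whether changing the group on the carbonyl carbon alters tolerance at all remains open.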